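The source may report more compounds than this note shows. Statements on the series, on what has been measured and on what is new or still open speak of the compounds shown alone.

Of the compounds shown here, two sharing one core have so far been measured in a functional assay on HUVEC cells (Homo sapiens) for inhibition, tested at 2.5 ug/mL; on this read-out higher numbers stand for a stronger effect at the one concentration tested and lower numbers for a weaker effect. Compound 1 `COc1cc(/C=C/C(=O)c2cccc(NC(=O)c3c(Cl)cccc3Cl)c2)ccc1O` carries a 2,6-dichlorophenyl on a carbonyl carbon, and in this assay compound 1 gives 53%. Compound 2 `COc1cc(/C=C/C(=O)c2cccc(NC(=O)c3cccs3)c2)ccc1O` carries a thiophen-2-yl on that carbonyl carbon instead, and in this assay compound 2 gives 71%, the higher of the two numbers measured, the nearest being compound 1.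

Compound 3 `COc1cc(/C=C/C(=O)c2cccc(NC(=O)c3cc(Cl)cc(Cl)c3)c2)ccc1O` has not yet been measured. Compared with compound 2 the change is 3,5-dichlorophenyl in place of thiophen-2-yl on a carbonyl carbon. Among the measured compounds shown here, only one measured step bears on this change: a number 18 percentage points higher from compound 1 to compound 2 (beyond the scatter), a modest gain on moving from a dichlorophenyl to thiophen-2-yl. Compound 3 moves back to a dichlorophenyl, though one with its two chlorines arranged differently from those in compound 1, so a step of about the same size in the opposite direction seems the most reasonable expectation, with real uncertainty because the arrangement differs. The step from compound 2 to compound 3 is therefore expected to be a number 15 percentage points lower from compound 2 to compound 3 (beyond the scatter). For compound 3 the estimate in this assay is 56%, with a range from 40% to 74%.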

Compound 3, a percentage reported as inhibition, at one concentration (the size of the read-out at that concentration, not a potency): 15%
Compound 3: the middle estimate sits 41 percentage points above what was measured; the measured number lies below the stated range.
By their numbers in this assay, from the lowest: compound 3; then compound 1; then compound 2.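

In this assay, this position, on the carbonyl carbon whose other neighbour is the amide-type nitrogen, responds strongly to where the chlorines sit: 2,6-dichlorophenyl and 3,5-dichlorophenyl hold the same atoms, yet the change gives a number 38 percentage points lower from compound 1 to compound 3 (beyond the scatter). "A dichlorophenyl" therefore cannot be treated as a single kind of group here, and the earlier step from one dichlorophenyl to thiophen-2-yl says little about dichlorophenyl groups in general, since replacing thiophen-2-yl with 3,5-dichlorophenyl gives a number 56 percentage points lower from compound 2 to compound 3 (beyond the scatter). No measurement offered here explains why the chlorine arrangement matters so much.

Among the compounds shown here, with only three compounds, it remains unclear whether the low number in compound 3 depends on both chlorines or on either one alone, which a plain phenyl or a phenyl carrying a single chlorine could help separate. As far as these compounds go, it also remains open whether thiophen-2-yl is unusually favourable or whether other groups at this position, such as a furyl ring, a short alkyl chain or a phenyl bearing an amine or a carboxylic acid, would match it.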